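Pyrazolylmethyl for fluorophenyl on the ether side chain

A few compounds are considered here, and "the series" means these few. Any claim that something is new, unique, unknown or untested is made for them only; others in the source may bear on it.

Compound 3, `Cc1nn(-c2ncnc3nc[nH]c23)c2c1C(OCc1ccc(F)cc1)CC(=O)N2`, is the reference point of this set. In a functional assay on HEK293 cells for agonist activity at G-protein coupled receptor 39 (Homo sapiens), read by scintillation proximity assay and inositol phosphate accumulation, with a stated time of 75 min (a lower number here means that less compound is needed, a higher number that more compound is needed for the effect), compound 3 gives 126 nM, the lowest number among the three measured compounds. Compound 1, `Cc1cc(C)n(CCOC2CC(=O)Nc3c2c(C)nn3-c2ncnc3nc[nH]c23)n1`, gives 2000 nM in this assay, and compound 2, `Cc1nn(-c2ncnc3nc[nH]c23)c2c1C(c1ccc(OC(C)C)cc1)CC(=O)N2`, gives 2700 nM; the step of a 1.4-fold higher number from compound 1 to compound 2 (0.13 log units; within the scatter) lies within the scatter, whereas a 16-fold lower number from compound 1 to compound 3 (1.20 log units; beyond the scatter) and a 21-fold lower number from compound 2 to compound 3 (1.33 log units; beyond the scatter) are both large and beyond it.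

Compound 4, `Cc1nn(-c2ncnc3nc[nH]c23)c2c1C(OCCn1cccn1)CC(=O)N2`, differs from compound 3 in one place: (1H-pyrazol-1-yl)methyl in place of 4-fluorophenyl on a saturated chain carbon bound to an oxygen on a saturated carbon. The step that bears most directly on this change is a 16-fold lower number from compound 1 to compound 3 (1.20 log units; beyond the scatter), since compound 1 carries a pyrazolylmethyl group with two additional methyl groups at the same position, and going from that group to the fluorophenyl of compound 3 lowered the number considerably. Compound 4 reverses this kind of exchange, with a pyrazole lacking the two methyls, so a large step upward from compound 3 is expected, roughly of the size seen between compound 1 and compound 3, though the absence of the methyls leaves some uncertainty about the exact extent.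

The expected step is a 12-fold higher number from compound 3 to compound 4 (1.08 log units; beyond the scatter). Compound 4 is therefore estimated at 1500 nM in this assay, with a likely range from 500 nM to 4500 nM.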

Compound 4, half-maximal effective concentration: 2270 nM
For compound 4 the middle estimate is 1.5-fold (0.18 log units) below the measured one; the measured number falls inside the stated range.
By their numbers in this assay, from the lowest: compound 3; then compounds 1, 4 and 2 (each within the scatter of the next).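

With the pyrazole now free of its methyl groups, the ether side chain of compound 3 proves just as sensitive to this exchange in this assay: the change to (1H-pyrazol-1-yl)methyl gives an 18-fold higher number from compound 3 to compound 4 (1.26 log units; beyond the scatter) and is large, so the earlier contrast with compound 1 did not depend on the two methyl groups. Those methyl groups themselves make no readable difference, as a 1.1-fold higher number from compound 1 to compound 4 (0.05 log units; within the scatter) stays within the scatter, and 2-(1H-pyrazol-1-yl)ethoxy on the saturated ring carbon is likewise not told apart from 4-isopropoxyphenyl, with a 1.2-fold lower number from compound 2 to compound 4 (0.08 log units; within the scatter) also within it. Among these four compounds, only compound 3, with its (4-fluorobenzyl)oxy group, stands apart, and nothing shown here gives a reason for the size of that step.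

Still open, as far as these compounds go, is whether the low number of compound 3 belongs to the fluorine or to the benzyl ring, which a plain benzyloxy or a 4-chlorobenzyloxy group at this place would separate. From the compounds shown here alone, it is also open how a longer chain between the oxygen and the ring, or an amine or a carboxylic acid on that chain, would read in this assay.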